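The source may report more compounds than this note shows. Statements on the series, on what has been measured and on what is new or still open speak of the compounds shown alone.

Series notes. Compound 1 `O=C1/C(=C/c2cccnc2)CNC/C1=C\c1ccccc1F` is the unsubstituted core carrying a fluoro group; in a functional assay on QGY-7703 cells (Homo sapiens) for cytotoxicity, read by MTT assay, with a stated time of 24 h (a lower number here means a stronger inhibitor, a higher number a weaker inhibitor), compound 1 gives 8890 nM. Compound 3 `O=C1/C(=C/c2ccncc2)CN(S(=O)(=O)c2ccc(F)cc2)C/C1=C\c1ccccc1F` carries a 4-fluorophenyl sulfonyl group on the ring nitrogen; in this assay compound 3 gives 9100 nM. Compound 2 `O=C1/C(=C/c2ccncc2)CN(S(=O)(=O)c2ccc(C(F)(F)F)cc2)C/C1=C\c1ccccc1F` is the matching 4-(trifluoromethyl)phenyl analogue; in this assay compound 2 gives 9500 nM. The difference between the two cores of compound 1 and compound 3 is not broken down here.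

Within the sulfonyl pair the change is trifluoromethyl in place of fluoro on an aromatic carbon and the step is a 1.0-fold higher number from compound 3 to compound 2 (0.02 log units; within the scatter).

Compound 4 `O=C1/C(=C/c2cccnc2)CNC/C1=C\c1ccccc1C(F)(F)F` is not yet measured. Its relation to compound 1 is trifluoromethyl in place of fluoro on an aromatic carbon. This is the same kind of change as that from compound 3 to compound 2, not the same: in the sulfonyl pair the place is para to a large group, whereas in compound 4 it is ortho to a large group, and the cores differ as noted.

Because a 1.0-fold higher number from compound 3 to compound 2 (0.02 log units; within the scatter) showed no movement, the step from compound 1 to compound 4 in this assay is expected to be about as small, a 1.0-fold higher number from compound 1 to compound 4 (0.01 log units; within the scatter). Compound 4 is therefore estimated at 9000 nM, with a range from 4500 nM to 18000 nM.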

Compound 4, half-maximal inhibitory concentration: 3800 nM
Beside the measured number, compound 4's estimate is 2.4-fold (0.37 log units) above it; the whole stated range lies above it.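

In this assay, trifluoromethyl in place of fluoro on the core of compound 1 gives a 2.3-fold lower number from compound 1 to compound 4 (0.37 log units; beyond the scatter), a modest step beyond the scatter, while the same change in the sulfonyl pair gives a 1.0-fold higher number from compound 3 to compound 2 (0.02 log units; within the scatter). Set side by side, the two steps cannot be told apart: the same change on two cores in this assay, a 1.0-fold higher number (0.02 log units; within the scatter) from compound 3 to compound 2 and a 2.3-fold lower number (0.37 log units; beyond the scatter) from compound 1 to compound 4, 2.4-fold (0.39 log units) apart, within the scatter of two such steps. For the compounds shown here, this shows no dependence of the change on the core, but it does not show that the change transfers from one core to another either, as there is only one pair per core and the two pairs also differ in where the change sits.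

Open, from the compounds shown here alone, is whether a chloro or methoxy group, ortho to a large group on the core of compound 1, would give a number nearer that of compound 1 or that of compound 4. Also open, going by these compounds, is whether the same step would appear with an acetyl group or a short alkyl chain on the ring nitrogen.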